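The source may hold more compounds than are shown below. What is called first, only, known or untested is meant among the compounds shown, and "the series" means these compounds.

Working notes on the series. The shared core of compound 1 `CC(C)c1onc(-c2c(Cl)cccc2Cl)c1COc1ccc(N(C)C(=O)c2ccc(C(=O)O)cc2)c(C(F)(F)F)n1` carries a methylated amide nitrogen on the aromatic ring; in a functional assay on HEK293 cells for agonist activity at Bile acid receptor (Homo sapiens), read by a luciferase reporter (a higher number here means a larger maximal response, a lower number a smaller maximal response), compound 1 gives 63%, the highest of the two numbers recorded. Within the data shown here, compound 2 `CC(C)c1onc(-c2c(Cl)cccc2Cl)c1COc1ccc(NC(=O)c2ccc(C(=O)O)cc2)c(C(F)(F)F)n1` gives 48%, and the step of a number 15 percentage points lower from compound 1 to compound 2 (beyond the scatter) is the only measured change at that nitrogen. Compound 3 `Cc1cc(C(F)(F)F)cc(OCc2c(-c3c(Cl)cccc3Cl)noc2C(C)C)n1`, which lacks any substituted nitrogen on that ring, is reported as "not active" (no number reported) without a number.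

Compound 4 `CC(C)c1onc(-c2c(Cl)cccc2Cl)c1COc1ccc(N(C)Cc2ccc(OCCO)cc2)c(C(F)(F)F)n1` differs from compound 1 by 4-(2-hydroxyethoxy)benzyl in place of (4-carboxyphenyl)carbonyl on a nitrogen on an aromatic ring. Among the measured compounds shown here, no measured step covers this exchange; the step from compound 1 to compound 2 only shows that altering that nitrogen changes the response modestly, and compound 3 shows the unsubstituted ring gives none. A downward step a number 28 percentage points lower from compound 1 to compound 4 (beyond the scatter) is therefore expected, with wide uncertainty. The estimate for compound 4 is 35%, between 5% and 65%.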

Compound 4, largest response reached (reported as efficacy), in percent of the reference or control that the assay uses: 59%
Beside the measured number, compound 4's estimate is 24 percentage points below it, and the stated range covers the measured number.
By their numbers in this assay, from the lowest: compound 2; then compounds 4 and 1 (each within the scatter of the next).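

In this assay, among these compounds, the step of a number 4 percentage points lower from compound 1 to compound 4 (within the scatter) shows that this nitrogen tolerates a far larger change than the earlier compounds covered. Compound 4 has neither the carbonyl on that nitrogen nor the carboxylic acid of compound 1, so neither group is needed for a response of this size. No measurement at hand explains this outcome. Going by these compounds, it remains open whether an amine or a longer chain in place of the 2-hydroxyethoxy group keeps the response. Also open, on these data alone, is whether hydrogen in place of methyl on the nitrogen of compound 4 lowers it, as in the amide pair.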